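This account rests on a few compounds, and the source may have more. Where it says the series, first, only, none or still open, it means among the compounds named here.

Compound 1 `COc1ccc(-c2ccc3ncc(-c4nnco4)c(NCCCn4ccnc4)c3c2)cc1` gives 30.1 ug/mL
Compound 2 `Nc1ccc(-c2ccc3ncc(-c4nnco4)c(NCCCn4ccnc4)c3c2)cc1` gives 30.2 ug/mL

For the measured compounds named here, in a physicochemical assay for solubility (a lower number here means a less soluble compound, a higher number a more soluble compound), compound 2 gives 30.2 ug/mL and lies within the scatter of compound 1, the only other number so far. Compound 3 `Cc1ccc(-c2ccc3ncc(-c4nnco4)c(NCCCn4ccnc4)c3c2)cc1` differs from it by methyl in place of amino on an aromatic carbon and carries methyl in place of amino on an aromatic carbon, para to a large group. Going by the values given here, one measured step bears on this: a 1.0-fold higher number from compound 1 to compound 2 (0.00 log units; within the scatter) put amino in place of methoxy on an aromatic carbon and stayed within the scatter. No step beyond the scatter is therefore expected in this assay and the estimate is a small one (a 1.2-fold lower number from compound 2 to compound 3 (0.07 log units; within the scatter)) with no firm direction. The expected value for compound 3 is 26 ug/mL (estimated range 11 ug/mL to 55 ug/mL).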

Compound 3, solubility: 0.3 ug/mL
For compound 3 the middle estimate is 87-fold (1.94 log units) above the measured one; the measured number lies below the stated range.
By their numbers in this assay, from the lowest: compound 3; then compounds 1 and 2 (each within the scatter of the next).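

In this assay, this position is not indifferent to what it carries: methyl in place of amino para to a large group gives a large step (a 100-fold lower number from compound 2 to compound 3 (2.00 log units; beyond the scatter)), and methyl in place of methoxy gives another (a 100-fold lower number from compound 1 to compound 3 (2.00 log units; beyond the scatter)). The earlier pair suggested a tolerant position, but among these three compounds the outcome depends on the group, with only methyl standing apart. Nothing measured here accounts for either step. As far as these compounds go, whether chlorine, ethyl or hydroxyl at this place would follow methyl or instead match amino and methoxy remains open.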